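A few compounds are considered here, and "the series" means these few. Any claim that something is new, unique, unknown or untested is made for them only; others in the source may bear on it.

In a functional assay on a cell-free system (plasma, Homo sapiens), with a stated time of 3 min (on this read-out lower numbers stand for stronger inhibition and higher numbers for weaker inhibition), three compounds have been measured so far; they share one core and differ only in the group on the saturated chain carbon bound to a carbonyl carbon and an oxygen on a saturated carbon. Compound 1 `CCCC[C@@H](O)C(=O)N1N=CC[C@H]1C(=O)NCc1cc(Cl)ccc1-n1cnnn1` gives 610 nM. Compound 2 `COC(C)(C)[C@@H](O)C(=O)N1N=CC[C@H]1C(=O)NCc1cc(Cl)ccc1-n1cnnn1` gives 3700 nM, which is a 6.1-fold higher number from compound 1 to compound 2 (0.78 log units; beyond the scatter). Compound 3 `Cc1cccc([C@@H](O)C(=O)N2N=CC[C@H]2C(=O)NCc2cc(Cl)ccc2-n2cnnn2)c1` gives 830 nM and stands second highest of the three numbers; the relevant steps are a 1.4-fold higher number from compound 1 to compound 3 (0.13 log units; within the scatter) and a 4.5-fold lower number from compound 2 to compound 3 (0.65 log units; beyond the scatter). Compound 4 `O=C(NCc1cc(Cl)ccc1-n1cnnn1)[C@@H]1CC=NN1C(=O)[C@H](O)c1ccccc1F` has not yet been measured in this assay. It differs from compound 3 by 2-fluorophenyl in place of 3-methylphenyl on a saturated chain carbon bound to a carbonyl carbon and an oxygen on a saturated carbon. Among the compounds with values here, none of the measured steps exchanges one aromatic ring for another, so there is no direct precedent. The closest guide is a 1.4-fold higher number from compound 1 to compound 3 (0.13 log units; within the scatter), where the 3-methylphenyl and the butyl gave numbers within the scatter of each other, while only the 1-methoxy-1-methylethyl of compound 2 stands apart. Exchanging one aromatic ring for another at the same place is therefore expected to give no step beyond the scatter in this assay. Compound 4 is estimated at 750 nM, with a range from 250 nM to 2200 nM, which corresponds to an expected step of a 1.1-fold lower number from compound 3 to compound 4 (0.04 log units; within the scatter).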

Compound 4, half-maximal inhibitory concentration: 1100 nM
Compound 4: middle estimate off by 1.5-fold (0.17 log units), on the low side; the measured number falls inside the stated range.
By their numbers in this assay, from the lowest: compounds 1, 3 and 4 (each within the scatter of the next); then compound 2.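

In this assay, the only exchange of one aromatic ring for another among these compounds, 2-fluorophenyl in place of 3-methylphenyl, gives a 1.3-fold higher number from compound 3 to compound 4 (0.12 log units; within the scatter) and so leaves the number within the scatter. The 2-fluorophenyl of compound 4 also stays within the scatter of the butyl group, with a 1.8-fold higher number from compound 1 to compound 4 (0.26 log units; within the scatter), but it stands apart from the 1-methoxy-1-methylethyl group, with a 3.4-fold lower number from compound 2 to compound 4 (0.53 log units; beyond the scatter), so that among the four compounds only compound 2 separates from the rest, while two different aromatic rings and a butyl chain cannot be told apart at this position. Nothing measured here accounts for why these groups give the numbers they do.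

The two rings differ in both the substituent and its location, so a 3-fluorophenyl or 2-methylphenyl group would be needed to separate these two changes, and an unsubstituted phenyl would show what either substituent contributes. Going by these compounds, it also remains open whether compound 2 stands apart through its branched carbon or its ether oxygen, which a tert-butyl group or a 3-methoxypropyl chain at the same place could help to settle.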